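Cytotoxicity notes: halogenated aryl variant of compound 2

The source may hold more compounds than are shown below. What is called first, only, known or untested is meant among the compounds shown, and "the series" means these compounds.

Compound 2 `Cc1ccc(C(O)c2cc(Cl)ccc2OCC(=O)Nc2ccc(S(N)(=O)=O)cc2C)cc1` gives 38700 nM in an ADME assay on C8166 cells (Homo sapiens) for cytotoxicity, read by MTT assay (on this read-out higher numbers stand for lower toxicity in this test and lower numbers for higher toxicity in this test), the highest of the three numbers recorded so far, although both neighbours sit within the scatter of it. Compound 1 `Cc1cc(S(N)(=O)=O)ccc1NC(=O)COc1ccc(Cl)cc1C(O)c1ccccc1` gives 33400 nM in this assay, and compound 3 `Cc1cc(C)cc(C(O)c2cc(Cl)ccc2OCC(=O)Nc2ccc(S(N)(=O)=O)cc2C)c1` gives 29400 nM in this assay. All measured steps are small: a 1.2-fold higher number from compound 1 to compound 2 (0.06 log units; within the scatter), a 1.1-fold lower number from compound 1 to compound 3 (0.06 log units; within the scatter) and a 1.3-fold lower number from compound 2 to compound 3 (0.12 log units; within the scatter). Compound 4 `Cc1cc(S(N)(=O)=O)ccc1NC(=O)COc1ccc(Cl)cc1C(O)c1cc(Cl)cc(Br)c1` differs from compound 2 by 3-bromo-5-chlorophenyl in place of 4-methylphenyl on a saturated chain carbon bound to an aromatic carbon and an oxygen on a saturated carbon. Within the data shown here, the steps that bear on this change are the two that exchange the same aryl group, a 1.1-fold lower number from compound 1 to compound 3 (0.06 log units; within the scatter) and a 1.3-fold lower number from compound 2 to compound 3 (0.12 log units; within the scatter), both within the scatter. Among the measured compounds shown here, none of the measured changes brings a halogen onto that ring, so the new change is only partly covered by what is known. Compound 4 is therefore expected to give a step of a 1.1-fold lower number from compound 2 to compound 4 (0.04 log units; within the scatter), not beyond the scatter. For compound 4 the estimate in this assay is 35000 nM, with a range from 17000 nM to 70000 nM.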

Compound 4, half-maximal cytotoxic concentration: 22900 nM
For compound 4 the middle estimate is 1.5-fold (0.18 log units) above the measured one, within the range that was stated.
By their numbers in this assay, from the lowest: compounds 4, 3, 1 and 2 (each within the scatter of the next).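

The first halogens on this ring, in 3-bromo-5-chlorophenyl, leave every step at this position within the scatter in this assay: a 1.7-fold lower number from compound 2 to compound 4 (0.23 log units; within the scatter) and a 1.3-fold lower number from compound 3 to compound 4 (0.11 log units; within the scatter) and also a 1.5-fold lower number from compound 1 to compound 4 (0.16 log units; within the scatter) all read the same way. The aryl groups on this saturated chain carbon now run from phenyl and its methyl-bearing forms to a ring carrying chlorine and bromine, and none of the four compounds stands beyond the scatter of another. No measurement at hand bears on why these numbers fall as they do.

The compounds shown leave open whether a ring with only chlorine or only bromine would read like 3-bromo-5-chlorophenyl. They also leave open whether an amine or a carboxylic acid on this ring would produce a step beyond the scatter.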